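The compounds below may be only part of what the source reports. "The series", "measured", "known", "first", "only" and "open" are said of these compounds alone.

Measured so far:
compound 1 `Cn1cc(-c2cc(C(C)(C)O)ccc2Oc2ccc(F)cc2F)c2cc(C(=O)NCc3ccc(C(=O)Nc4ccccc4N)cc3)[nH]c2c1=O` — 90 nM
compound 2 `Cn1cc(-c2ccccc2Oc2ccccc2)c2cc(C(=O)NCCCCC(=O)NO)[nH]c2c1=O` — 180 nM

Both compounds were tested in a functional assay on MV4-11 cells (Homo sapiens) for antiproliferative activity, read by CCK-8 assay, with a stated time of 72 h; a lower number here means a stronger inhibitor, a higher number a weaker inhibitor. Compound 1 gives 90 nM and compound 2 gives 180 nM; the gap between the two is within the scatter of repeated measurements, so the two numbers cannot be told apart and neither compound can be called the stronger of the pair. Compound 1 thus stands as one of two equivalent values, with no other point of comparison in the set.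

The next compound, compound 3 `COc1ccc(C(C)(C)O)cc1-c1cn(C)c(=O)c2[nH]c(C(=O)NCc3ccc(C(=O)Nc4ccccc4N)cc3)cc12`, has not been measured. It differs from compound 1 in one place: methyl in place of 2,4-difluorophenyl on an oxygen on an aromatic ring. The change is a large cut, since the whole 2,4-difluorophenyl group on the ether oxygen is removed and only a methyl remains there; the rest of the shared core and the benzamide side chain are unchanged. Within the data shown here, no measured pair in the set shows this change, so its size is unknown. A step beyond the scatter toward a weaker compound is expected, of the order of a 3.9-fold higher number from compound 1 to compound 3 (0.59 log units; beyond the scatter). For compound 3 the estimate is 350 nM, with a range from 80 nM to 1500 nM.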

Compound 3, half-maximal inhibitory concentration: 420 nM
The estimate for compound 3 lay 1.2-fold (0.08 log units) below the measured number, within the range that was stated.
By their numbers in this assay, from the lowest: compounds 1 and 2 (each within the scatter of the next); then compound 3.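

In this assay, among these compounds, the change from 2,4-difluorophenoxy to methoxy gives a 4.7-fold higher number from compound 1 to compound 3 (0.67 log units; beyond the scatter) and so provides the first readable step, one beyond the scatter. At this place, on an oxygen on an aromatic ring, the group therefore affects the read-out: with the shared core and the benzamide side chain unchanged, the 2,4-difluorophenyl group goes with the lower number and methyl with the higher, while compound 3 still gives a value in the nanomolar range at 420 nM and the step remains modest. Nothing at hand bears on the cause of this step, which rests on this single pair.

The pair leaves open whether the step follows the aromatic ring or the two fluorines, as both leave together in the same change. An ethyl group or a longer alkyl chain on the oxygen, or an amine in place of the oxygen, would show whether the number moves gradually between these two ends or depends on an aromatic ring at this place.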